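Shifting the double bond along the acid chain

A few compounds are considered here, and "the series" means these few. Any claim that something is new, unique, unknown or untested is made for them only; others in the source may bear on it.

Values in an ADME assay on the whole organism (strain CD-1) for pharmacokinetics, with Mus musculus as the target, at a dose of 3 mg/kg by the intravenous route; on this read-out lower numbers stand for lower exposure and higher numbers for higher exposure at the dose given:
- compound 1 `CN(Cc1ccccc1OCCC[C@@H]1C[C@@H]1C(=O)O)C(=O)c1ccc(-c2ccco2)cc1`: 30100 ng.h/mL
- compound 2 `CN(Cc1ccccc1OCCC[C@@H]1C[C@H]1C(=O)O)C(=O)c1ccc(-c2ccco2)cc1`: 40500 ng.h/mL
- compound 3 `C/C(=C\C(=O)O)CCCOc1ccccc1CN(C)C(=O)c1ccc(-c2ccco2)cc1`: 4700 ng.h/mL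

Compound 3 is lowest of the three, with steps of a 6.4-fold lower number from compound 1 to compound 3 (0.81 log units; beyond the scatter) and an 8.6-fold lower number from compound 2 to compound 3 (0.94 log units; beyond the scatter). The remaining step, a 1.3-fold higher number from compound 1 to compound 2 (0.13 log units; within the scatter), involves no change of connectivity.

Compound 4 `C/C(=C\COc1ccccc1CN(C)C(=O)c1ccc(-c2ccco2)cc1)CCC(=O)O` differs from compound 3 as follows: 4-carboxy-2-methylbut-1-en-1-yl in place of 4-carboxy-3-methylbut-3-en-1-yl on a saturated chain carbon bound to an oxygen on an aromatic ring. Among the compounds with values here, no measured step covers this change. The two larger steps replace 2-carboxycyclopropyl with 2-carboxy-1-methylethenyl, so they bear on it only indirectly, and both compound 3 and compound 4 keep an open chain with no ring. The expected step is a 1.2-fold lower number from compound 3 to compound 4 (0.07 log units; within the scatter), with none expected beyond the scatter. The estimate for compound 4 is 4000 ng.h/mL, with an expected range of 1300 ng.h/mL to 12000 ng.h/mL.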

Compound 4, area under the concentration-time curve: 3300 ng.h/mL
The estimate for compound 4 lay 1.2-fold (0.08 log units) above the measured number; the range from low to high includes it.
By their numbers in this assay, from the lowest: compounds 4 and 3 (each within the scatter of the next); then compounds 1 and 2 (each within the scatter of the next).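

In this assay, moving the double bond along the open chain, from 4-carboxy-3-methylbut-3-en-1-yl to 4-carboxy-2-methylbut-1-en-1-yl, gives a 1.4-fold lower number from compound 3 to compound 4 (0.15 log units; within the scatter), so its place on this chain makes no difference beyond the scatter. The gap to the cyclopropane acids persists with the shifted double bond, with a 12-fold lower number from compound 2 to compound 4 (1.09 log units; beyond the scatter) and a 9.1-fold lower number from compound 1 to compound 4 (0.96 log units; beyond the scatter). Nothing available here accounts for the size of these steps.

Going by these compounds, whether that gap follows the cyclopropane ring or the double bond stays open. A fully saturated open chain carrying the same carboxylic acid would separate the two.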